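A few compounds are considered here, and "the series" means these few. Any claim that something is new, unique, unknown or untested is made for them only; others in the source may bear on it.

Measured so far in an assay for inhibition of beta-glucuronidase (Bos taurus), read by spectrophotometry, with a stated time of 30 min; on this read-out higher numbers stand for weaker inhibition and lower numbers for stronger inhibition:
compound 1, `Fc1ccccc1C(c1c[nH]c2ccc(Br)cc12)c1c[nH]c2ccc(Br)cc12`, gives 18400 nM
compound 2, `Clc1cccc(C(c2c[nH]c3ccc(Br)cc23)c2c[nH]c3ccc(Br)cc23)c1`, gives 22300 nM
compound 3, `Oc1ccc(C(c2c[nH]c3ccc(Br)cc23)c2c[nH]c3ccc(Br)cc23)cc1`, gives 1860 nM

Among these three numbers compound 3 stands lowest in this assay; the two steps leading to it are a 9.9-fold lower number from compound 1 to compound 3 (1.00 log units; beyond the scatter) and a 12-fold lower number from compound 2 to compound 3 (1.08 log units; beyond the scatter), both beyond the scatter.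

Compound 4, `Clc1ccc(C(c2c[nH]c3ccc(Br)cc23)c2c[nH]c3ccc(Br)cc23)cc1Cl`, has not yet been measured. It differs from compound 3 in one place: 3,4-dichlorophenyl in place of 4-hydroxyphenyl on a saturated chain carbon bound to two aromatic carbons. The relevant comparisons are the two compounds that carry 2-fluorophenyl and 3-chlorophenyl on that carbon, compounds 1 and 2. Between them the step of a 1.2-fold higher number from compound 1 to compound 2 (0.08 log units; within the scatter) lies within the scatter, whereas the change to 4-hydroxyphenyl gave the large steps noted above. Putting a chlorinated phenyl back in place of 4-hydroxyphenyl is therefore expected to undo most of that gain, giving a number close to those of compounds 1 and 2. Compound 4 is expected to come in at 18000 nM in this assay, within a range of 6000 nM to 50000 nM. This corresponds to an expected step of a 9.7-fold higher number from compound 3 to compound 4 (0.99 log units; beyond the scatter).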

Compound 4, half-maximal inhibitory concentration: 21500 nM
Compound 4: middle estimate off by 1.2-fold (0.08 log units), on the low side; low and high end bracket the measured number.
By their numbers in this assay, from the lowest: compound 3; then compounds 1, 4 and 2 (each within the scatter of the next).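

In this assay, putting 3,4-dichlorophenyl in place of 4-hydroxyphenyl on the saturated chain carbon bound to two aromatic carbons gives a large step (a 12-fold higher number from compound 3 to compound 4 (1.06 log units; beyond the scatter)), so a third halogen-bearing phenyl group also stands well apart from compound 3. Chloro in place of hydrogen on an aromatic carbon leaves the number unchanged within the scatter (a 1.0-fold lower number from compound 2 to compound 4 (0.02 log units; within the scatter)), and the comparison with the 2-fluorophenyl compound also stays within it (a 1.2-fold higher number from compound 1 to compound 4 (0.07 log units; within the scatter)), so compounds 1, 2 and 4 cannot be told apart. Nothing available accounts for the separate position of compound 3.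

On these data alone, it remains open whether the low number of compound 3 is specific to its hydroxyl group or would be shared by a phenyl group carrying a methoxy group, an amine or a carboxylic acid. As far as these compounds go, the contribution of the bromo groups on the shared core also remains open, since all four compounds carry them.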